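One ring stereocentre inverted on a long-chain compound

The source may hold more compounds than are shown below. What is called first, only, known or untested is meant among the compounds shown, and "the series" means these compounds.

Measured so far in a functional assay on L1210 cells (Mus musculus) for cytotoxicity; on this read-out lower numbers stand for stronger inhibition and higher numbers for weaker inhibition 
- compound 1 `CC(C)CC[C@H](O)CCCCCCCCC[C@@H]1N[C@@H](CO)[C@@H]1O` gives 2.9 ug/mL 
- compound 2 `CCCCCCCCCCCCCC[C@@H]1N[C@@H](CO)[C@@H]1O` gives 4.5 ug/mL 

Compound 2 lies within the usual scatter of compound 1, so the two cannot be ranked. Compound 3 `CCCCCCCCCCCCCC[C@@H]1N[C@H](CO)[C@@H]1O` has the same atoms and bonds as compound 2. The difference is the two compounds have the same atoms and bonds and differ only in configuration as drawn: 1 of 3 stereo elements differ; a stereocentre at a saturated ring carbon is drawn S in compound 2 and R in compound 3, with a stereocentre at a saturated ring carbon drawn S in compound 2 and R in compound 3. Among the measured compounds shown here, the only measured step, a 1.6-fold higher number from compound 1 to compound 2 (0.19 log units; within the scatter), alters the chain and leaves configuration untouched, so it offers no guide to this change. For the measured compounds named here, no measured pair tests a stereocentre, and the size and direction of any effect remain open. The estimate therefore starts from compound 2 at 4.5 ug/mL with no shift argued in either direction, and with wide margins. The expected change is no change at the digits printed from compound 2 to compound 3 (within the scatter) in this estimate. For compound 3 the estimated value is 4.5 ug/mL, with an expected range from 1.5 ug/mL to 13 ug/mL.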

Compound 3, half-maximal inhibitory concentration: 7.5 ug/mL
For compound 3 the middle estimate is 1.7-fold (0.22 log units) below the measured one, and the stated range covers the measured number.
By their numbers in this assay, from the lowest: compounds 1, 2 and 3 (each within the scatter of the next, the first and the last beyond it).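

Among the compounds shown here, this is the first measured test of configuration: redrawing one saturated ring carbon from S to R gives a 1.7-fold higher number from compound 2 to compound 3 (0.22 log units; within the scatter) in this assay. A step of this size gives no ground for ranking the two drawings, so inverting this stereocentre has no demonstrated effect on the read-out, although a small effect cannot be excluded. The comparison is a clean one, as nothing else separates the pair: the fact that compounds 2 and 3 differ only in the configuration as drawn

The other two stereocentres of the shared core remain untested, and the compounds shown do not tell whether the same inversion would give a similar step on the hydroxylated chain of compound 1. They also leave open how the read-out would respond to a carboxylic acid in place of the hydroxymethyl group.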